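Removing the carbamoyl side chain of compound 2

The source may report more compounds than this note shows. Statements on the series, on what has been measured and on what is new or still open speak of the compounds shown alone.

Measured compounds in a functional assay on HL-60 cells (Homo sapiens) for antiproliferative activity, read by MTT assay, with a stated time of 48 h; on this read-out higher numbers stand for weaker inhibition and lower numbers for stronger inhibition:
compound 1 `O=C(CC[C@H](NC(=O)c1cc2ccccc2cn1)C(=O)OCc1ccccc1)OCc1ccccc1` gives 83.6 nM
compound 2 `NC(=O)C[C@H](NC(=O)c1cc2ccccc2cn1)C(=O)OCc1ccccc1` gives 86.9 nM
compound 3 `CSCC[C@H](NC(=O)c1cc2ccccc2cn1)C(=O)OCc1ccccc1` gives 44.9 nM

Compound 2 sits within the scatter of both neighbours: the step of a 1.0-fold higher number from compound 1 to compound 2 (0.02 log units; within the scatter) is flat, and the step of a 1.9-fold lower number from compound 2 to compound 3 (0.29 log units; within the scatter) stays inside the scatter too, as does a 1.9-fold lower number from compound 1 to compound 3 (0.27 log units; within the scatter). Compound 4 `C[C@H](NC(=O)c1cc2ccccc2cn1)C(=O)OCc1ccccc1` differs from compound 2 by hydrogen in place of carbamoyl on a saturated chain carbon, two bonds along the chain from an amide-type nitrogen and a carbonyl carbon. The two steps that touch this position, the carbamoyl exchange in a 1.9-fold lower number from compound 2 to compound 3 (0.29 log units; within the scatter) and the side-chain swap in a 1.0-fold higher number from compound 1 to compound 2 (0.02 log units; within the scatter), both remained within scatter, so no step beyond the scatter is expected for this assay, in either direction. Compound 4 is therefore estimated at 100 nM, between 40 nM and 300 nM, a step of a 1.2-fold higher number from compound 2 to compound 4 (0.06 log units; within the scatter) that is expected to stay within scatter.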

Compound 4, half-maximal inhibitory concentration: 84.8 nM
For compound 4 the middle estimate is 1.2-fold (0.07 log units) above the measured one, within the range that was stated.
By their numbers in this assay, from the lowest: compounds 3, 1, 4 and 2 (each within the scatter of the next).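

In this assay the read-out shows a 1.0-fold lower number from compound 2 to compound 4 (0.01 log units; within the scatter) on losing carbamoyl, a 1.0-fold higher number from compound 1 to compound 4 (0.01 log units; within the scatter) on losing (benzyloxycarbonyl)methyl and a 1.9-fold higher number from compound 3 to compound 4 (0.28 log units; within the scatter) on losing (methylsulfanyl)methyl. The earlier compounds shown here only exchanged one full side chain for another, whereas compound 4 shows that with hydrogen in their place the number stays within the scatter of all three. No measurement given here offers an explanation for this. From the compounds shown here alone, whether an amine, a carboxylic acid or a longer chain at this position would give a step beyond the scatter stays open.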